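This account rests on a few compounds, and the source may have more. Where it says the series, first, only, none or still open, it means among the compounds named here.

The account concerns two measured compounds and one not yet measured. Going by the values given here, compound 1 `CC(C)n1cc(-c2ccnc3[nH]c(C4CCNCC4)cc23)ccc1=O` and compound 2 `COc1cc(F)ccc1-c1ccnc2[nH]c(C3CCOCC3)cc12` share a core, while compound 3 `CC(C)n1cc(-c2ccnc3[nH]c(C4CCN(CC(=O)N(C)C)CC4)cc23)ccc1=O` is the one awaiting a number. In an ADME assay on microsomes from liver (Homo sapiens) for metabolic stability (on this read-out lower numbers stand for slow clearance and higher numbers for fast clearance), compound 1 gives < 3 uL/min, which is a limit of the assay rather than a number. In this assay compound 2 gives 10 uL/min. Compound 1 therefore sits at the limit of < 3 uL/min in this assay, at which 1 of the 2 values shown sits, so its true clearance is only bounded from above. Compound 3 differs from compound 1 by (dimethylcarbamoyl)methyl in place of hydrogen on an amine nitrogen in a ring. Among the compounds with values here, no measured pair shows what this change does here. The step of an at least 1.6-fold higher number from compound 1 to compound 3 (0.22 log units; that floor lies within the scatter) is expected to be a modest rise in clearance, possibly within the scatter, possibly just beyond it. On that basis compound 3 is estimated at 5 uL/min, with a plausible range from 2 uL/min to 15 uL/min, and a fair chance that the assay again reports only a limit.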

Compound 3, intrinsic clearance in a liver preparation (reported as CLH), per the amount of preparation that the assay uses: < 3 uL/min
Compound 3: a limit, no number; the forecaster's own chance of this, stated with the estimate: 40%; middle value at least 1.6-fold (0.22 log units) away from the limit.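

No step can be read from compound 1 to compound 3, since both results in this assay are limits of the assay, not numbers: the limit of < 3 uL/min in this assay, at which 2 of the 3 values shown sit.

The compounds shown leave open how (dimethylcarbamoyl)methyl in place of hydrogen on an amine nitrogen in a ring alters clearance, if it does at all.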